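Adding a Nitro Group: What Permeability to Expect

The compounds below may be only part of what the source reports. "The series", "measured", "known", "first", "only" and "open" are said of these compounds alone.

Of the compounds shown here, three that share one core have been measured in an ADME assay for permeability, using PAMPA; on this read-out higher numbers stand for higher permeability and lower numbers for lower permeability. Compound 1 `CN(C)CCC(=O)Nc1cccc(-c2nc3ccccc3s2)c1` gives 2080 10^-6 cm/s. Compound 2 `O=C(Nc1cccc(-c2nc3ccccc3s2)c1)c1cccnc1Cl` gives 677 10^-6 cm/s in this assay, the second highest of the three numbers. Compound 3 `O=C(Nc1cccc(-c2nc3ccccc3s2)c1)c1ccc(Cl)nc1Cl` gives 104 10^-6 cm/s in this assay. Compound 2 thus sits between the other two: the step of a 3.1-fold lower number from compound 1 to compound 2 (0.49 log units; beyond the scatter) lies beyond the scatter, and so does the step of a 6.5-fold lower number from compound 2 to compound 3 (0.81 log units; beyond the scatter). The wider step a 20-fold lower number from compound 1 to compound 3 (1.30 log units; beyond the scatter) is larger still.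

Compound 4 `O=C(Nc1cccc(-c2nc3ccccc3s2)c1)c1cc([N+](=O)[O-])cnc1Cl` has not yet been measured in this assay. It differs from compound 2 in one place: nitro in place of hydrogen on an aromatic carbon. Within the data shown here, no measured step adds a nitro group, so the closest guide is the step of a 6.5-fold lower number from compound 2 to compound 3 (0.81 log units; beyond the scatter), where a chloro group replaced a hydrogen on an aromatic carbon of the same core and the number went down. A nitro group is a larger addition than a chloro group, so a drop of similar or somewhat greater size seems likely. Compound 4 is therefore expected to show a lowering step, a 3.8-fold lower number from compound 2 to compound 4 (0.58 log units; beyond the scatter), in this assay. The estimate for compound 4 in this assay is 180 10^-6 cm/s, with a range from 60 10^-6 cm/s to 500 10^-6 cm/s.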

Compound 4, apparent permeability: 42 10^-6 cm/s
Beside the measured number, compound 4's estimate is 4.3-fold (0.63 log units) above it, and the stated range ends above it.
By their numbers in this assay, from the lowest: compound 4; then compound 3; then compound 2; then compound 1.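

Placing nitro on this carbon, two atoms from the ring nitrogen and para to the chloro group, brings a 16-fold lower number from compound 2 to compound 4 (1.21 log units; beyond the scatter) in this assay and leaves compound 4 with the lowest number of the four compounds. The earlier chloro addition on the same ring gave a 6.5-fold lower number from compound 2 to compound 3 (0.81 log units; beyond the scatter) and counts as modest, whereas the nitro step counts as large, so the ring of compound 2 has now lost permeability with two different added groups, and the size of the fall is not the same for both. The nitro group brings three heavy atoms and two hydrogen-bond acceptors with no net charge, but nothing measured here tells which of these features matters or explains a fall of this size.

The chloro of compound 3 sits on a different ring carbon, so the compounds shown leave open how much of the difference between the two steps comes from the group and how much from its place. Also open, as far as these compounds go, is whether an amine, a methoxy group or a carboxylic acid on this same carbon would lower the number too, or whether a fall this large belongs to nitro alone.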